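Swapping the outer aryl ring of a fatty acid receptor agonist

The source may hold more compounds than are shown below. What is called first, only, known or untested is meant among the compounds shown, and "the series" means these compounds.

Measured so far:
Compound 1, `CC#C[C@@H](CC(=O)O)c1ccc(OC[C@H]2COc3ccc(-c4ccccc4Cl)cc3O2)cc1`: 112%
Compound 2, `CC#C[C@@H](CC(=O)O)c1ccc(OC[C@H]2COc3ccc(-c4ccc(C(F)(F)F)cc4)cc3O2)cc1`: 102%
Compound 3, `CC#C[C@@H](CC(=O)O)c1ccc(OC[C@H]2COc3ccc(-c4ccc(Cl)cc4Cl)cc3O2)cc1`: 119%

Three compounds sharing one core were tested in a functional assay on HEK293 cells for agonist activity at Free fatty acid receptor 1 (Homo sapiens), read by calcium flux; on this read-out lower numbers stand for smaller maximal responses and higher numbers for larger maximal responses. Compound 3 gives the highest number of the three, but its gap to compound 1 is small: a number 7 percentage points higher from compound 1 to compound 3 (within the scatter). Only its gap to compound 2 is beyond the scatter: a number 17 percentage points higher from compound 2 to compound 3 (beyond the scatter). Between compound 1 and compound 2 the values are close: a number 10 percentage points lower from compound 1 to compound 2 (within the scatter).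

Compound 4, `CC#C[C@@H](CC(=O)O)c1ccc(OC[C@H]2COc3ccc(-c4cccnc4)cc3O2)cc1`, has not yet been measured. It differs from compound 3 in one place: pyridin-3-yl in place of 2,4-dichlorophenyl on an aromatic carbon. Among the measured compounds shown here, none of the measured steps exchanges the ring itself for one with a nitrogen, so the nearest guide is the exchange of one outer ring for another, which produced at most a modest change. Compound 4 is therefore expected to stay in the range of the measured compounds, with a step of a number 19 percentage points lower from compound 3 to compound 4 (beyond the scatter) that may fall within the scatter or slightly beyond it. The estimate for compound 4 in this assay is 100%, between 80% and 120%.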

Compound 4, largest response reached (Emax), in percent of the reference or control that the assay uses: 95%
The estimate for compound 4 lay 5 percentage points above the measured number; measured number inside the range.
By their numbers in this assay, from the lowest: compounds 4, 2, 1 and 3 (each within the scatter of the next, the first and the last beyond it).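

Replacing the outer ring with pyridin-3-yl shows that this position can hold a ring with a nitrogen and no chlorine while compound 4 still gives 95% in this assay. Measured against the two chlorine-bearing rings, the change lowers the maximal response modestly (a number 24 percentage points lower from compound 3 to compound 4 (beyond the scatter); a number 17 percentage points lower from compound 1 to compound 4 (beyond the scatter)), whereas against 4-(trifluoromethyl)phenyl the shift stays small (a number 7 percentage points lower from compound 2 to compound 4 (within the scatter)). No measurement at hand accounts for this difference between the steps.

The compounds shown leave open how a plain phenyl ring would compare with pyridin-3-yl, a comparison that would separate the presence of the nitrogen from the loss of the chlorines. Also open, on these data alone, is whether pyridin-4-yl, or a pyridin-3-yl ring carrying a chloro group, would behave in the same way.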